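Chloro Substitution on Two Dithiocarbamate Chromone Cores

A few compounds are considered here, and "the series" means these few. Any claim that something is new, unique, unknown or untested is made for them only; others in the source may bear on it.

Compound 1 `O=c1c(SC(=S)N2CCCCC2)coc2ccccc12` and compound 2 `O=c1cc(CSC(=S)N2CCCC2)oc2ccccc12` differ in how the same atoms are joined; the difference between the two cores is not broken down here. In a functional assay on LM7 cells (Homo sapiens) for antiproliferative activity, read by MTT assay, with a stated time of 72 h (a lower number here means a stronger inhibitor, a higher number a weaker inhibitor), compound 1 gives 7800 nM, while compound 2 gives 40000 nM. Compound 3 `O=c1cc(CSC(=S)N2CCCC2)oc2cc(Cl)ccc12` reaches only a limit of the assay, > 25000 nM. The change from compound 2 to compound 3 is chloro in place of hydrogen on an aromatic carbon; the step that the limit leaves unreadable from compound 2 to compound 3 cannot be read because of the limit of > 25000 nM in this assay, at which 1 of the 3 values shown sits. Compound 4 `O=c1c(SC(=S)N2CCCCC2)coc2ccc(Cl)cc12` carries the same change on the core of compound 1, namely (chloro in place of hydrogen on an aromatic carbon). Among the measured compounds shown here, since the one measured step of this change is unreadable, the expectation for compound 4 rests on compound 1 giving 7800 nM and on the change being small: a step of a 1.2-fold higher number from compound 1 to compound 4 (0.06 log units; within the scatter) is expected. Compound 4 is therefore estimated at 9000 nM, between 3000 nM and 30000 nM.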

Compound 4, half-maximal inhibitory concentration: > 25000 nM
Compound 4 gave a limit, no number; the forecaster's own chance of this, stated with the estimate: 20%; middle value at least 2.7-fold (0.44 log units) away from the limit.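

In this assay, chloro in place of hydrogen on the core of compound 1 gives an at least 3.2-fold higher number from compound 1 to compound 4 (0.50 log units; beyond the scatter), so on this core the change weakens the compound beyond the scatter. Among the compounds shown here, the step from compound 2 to compound 3 cannot be read, so there is no second measured step to set beside this one, and nothing shows whether the change acts alike on both cores. The full size of the step on the core of compound 1 also stays unknown, since both chloro compounds end at a limit: the limit of > 25000 nM in this assay, at which 2 of the 4 values shown sit.

The compounds shown leave open whether fluoro or methoxy on the same aromatic carbon would hold the activity of compound 1. They also leave open what an amine or a carboxylic acid there would do.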